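Aryl substituent swap at the para position of the core

A few compounds are considered here, and "the series" means these few. Any claim that something is new, unique, unknown or untested is made for them only; others in the source may bear on it.

Measured so far:
compound 1 `CC(c1ccc(-c2ccccc2)c(F)c1)c1nnc2n1N=C(c1ccc(Cl)cc1)CS2`: 8700 nM
compound 2 `COc1ccc2cc(C(C)c3nnc4n3N=C(c3ccc(C(F)(F)F)cc3)CS4)ccc2c1`: 6900 nM
compound 3 `COc1ccc2cc(C(C)c3nnc4n3N=C(c3ccc([N+](=O)[O-])cc3)CS4)ccc2c1`: 18800 nM

All three numbers come from a functional assay on MCF7 cells (Homo sapiens) for inhibition, read by sulforhodamine B assay, with a stated time of 72 h; on this read-out higher numbers stand for weaker inhibition and lower numbers for stronger inhibition. Compound 1 stands second highest of the three: next to compound 2 the gap is within the scatter, so no order between the two is claimed; compound 3 alone lies beyond the scatter above compound 1.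

Compound 4 `COc1ccc(C2=Nn3c(nnc3C(C)c3ccc(-c4ccccc4)c(F)c3)SC2)cc1` is not yet measured. It differs from compound 1 as follows: methoxy in place of chloro on an aromatic carbon

Going by the values given here, the one measured step, a 2.7-fold higher number from compound 2 to compound 3 (0.44 log units; beyond the scatter), concerns a different pair of groups on the same ring position of a different core variant, and is modest in size; it does not involve either chloro or methoxy. Among the compounds with values here, no measured pair shows the chloro to methoxy exchange, so nothing speaks for a step beyond the scatter in either direction in this assay.

The expectation for compound 4 is therefore a number close to that of compound 1, with the step of a 1.0-fold higher number from compound 1 to compound 4 (0.01 log units; within the scatter) expected to stay within the scatter. Compound 4 is estimated at 9000 nM, in the range 4000 nM to 20000 nM.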

Compound 4, half-maximal inhibitory concentration: 2600 nM
Compound 4: middle estimate off by 3.5-fold (0.54 log units), on the high side; measured number outside the range, below it.
By their numbers in this assay, from the lowest: compound 4; then compounds 2 and 1 (each within the scatter of the next); then compound 3.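

In this assay, the change from 4-chlorophenyl to 4-methoxyphenyl gives a 3.3-fold lower number from compound 1 to compound 4 (0.52 log units; beyond the scatter), which shows that this ring position responds beyond the scatter to an exchange of chloro for methoxy with the rest of compound 1 held constant. The earlier step at this position, a 2.7-fold higher number from compound 2 to compound 3 (0.44 log units; beyond the scatter), involves other groups on a different core variant and runs the opposite way in number, so the two steps share no group and do not form one scale of substituents. Nothing available here accounts for the size or direction of the new step.

The compounds shown leave open whether methoxy in place of chloro gives a step of similar size on the other core variant, since only one pair carries this exchange. They also leave open how this position reads in this assay with an amine, a hydroxy group or a longer alkoxy chain such as ethoxy in place of methoxy.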